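Swapping Fluoro for Ethoxycarbonyl on an Aryl Aziridine Urea

The compounds below may be only part of what the source reports. "The series", "measured", "known", "first", "only" and "open" are said of these compounds alone.

Compound 1 `CCOC(=O)CNC(=O)N1CC1C#N` — 17000 nM
Compound 2 `N#CC1CN1C(=O)Nc1ccc(F)cc1` — 2400 nM

In a functional assay on MCF7 cells (Homo sapiens) for inhibition (a lower number here means a stronger inhibitor, a higher number a weaker inhibitor), compound 2 gives 2400 nM, the lowest of the two numbers. Compound 1 gives 17000 nM, a higher number that lies beyond the scatter. Compound 3 `CCOC(=O)c1ccc(NC(=O)N2CC2C#N)cc1` differs from compound 2 in one place: ethoxycarbonyl in place of fluoro on an aromatic carbon. Among the compounds with values here, no step between measured compounds speaks to this change, so only a modest step in this assay is expected, possibly none beyond the scatter. Compound 3 is therefore estimated at 2500 nM, with a range from 600 nM to 10000 nM. The expected step is a 1.0-fold higher number from compound 2 to compound 3 (0.02 log units; within the scatter).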

Compound 3, half-maximal inhibitory concentration: 2100 nM
Beside the measured number, compound 3's estimate is 1.2-fold (0.08 log units) above it; the measured number falls inside the stated range.
By their numbers in this assay, from the lowest: compounds 3 and 2 (each within the scatter of the next); then compound 1.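

In this assay, the aromatic carbon para to a group of 8 heavy atoms takes ethoxycarbonyl in place of fluoro with a 1.1-fold lower number from compound 2 to compound 3 (0.06 log units; within the scatter). Within the data shown here, a group of 5 heavy atoms with 2 hydrogen-bond acceptors therefore stands here in place of a single fluorine without a step beyond the scatter, something the earlier compounds could not show. Nothing available gives a reason for this result.

Going by these compounds, whether a carboxylic acid or an amine on this aromatic carbon would leave the number as little moved remains open. So does the outcome for a longer chain at this place.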